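This account rests on a few compounds, and the source may have more. Where it says the series, first, only, none or still open, it means among the compounds named here.

Compound 3 `COc1ccc(/C=C2\CCC/C(=C\c3cccc(Cl)c3)C2=O)cc1OC` gives 6000 nM in a functional assay on MCF7 cells (Homo sapiens) for cytotoxicity, read by MTT assay, with a stated time of 72 h (on this read-out higher numbers stand for weaker inhibition and lower numbers for stronger inhibition), and stands as the lowest of the numbers shown. Compound 1 `COc1ccc(/C=C2\CCC/C(=C\c3cccc(OC)c3OC)C2=O)cc1` lies nearest to it, with 18600 nM in this assay, a gap beyond the scatter. Compound 2 `COc1cccc(/C=C2\CCC/C(=C\c3ccc(Cl)cc3Cl)C2=O)c1OC` reaches only the limit of this assay, > 20000 nM, so for it no number is known. Compound 4 `COc1cc(/C=C2\CCC/C(=C\c3ccc(OC)c(OC)c3)C2=O)ccc1O` has not yet been measured in this assay. It differs from compound 3 by 4-hydroxy-3-methoxyphenyl in place of 3-chlorophenyl on a double-bonded chain carbon bound to a double-bonded ring carbon. Going by the values given here, only one measured step exchanges an aryl group on this chain carbon, namely an at least 1.0-fold higher number from compound 1 to compound 2 (0.03 log units; that floor lies within the scatter), and its true size is hidden because it rests on (the limit of > 20000 nM in this assay, at which 1 of the 3 values shown sits). Among the compounds with values here, no measured step introduces a 4-hydroxy-3-methoxyphenyl group anywhere. Compound 4 carries two oxygen-bearing rings, as compound 1 does, whereas compound 3 carries a chlorine-bearing ring on the chain carbon in question; compound 1 gives a higher number than compound 3. The author therefore expects compound 4 to give a higher number than compound 3, a step of a 1.7-fold higher number from compound 3 to compound 4 (0.22 log units; within the scatter), while allowing that the change may fall within the scatter. The estimate for compound 4 in this assay is 10000 nM, with a range from 3000 nM to 25000 nM.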

Compound 4, half-maximal inhibitory concentration: 7900 nM
The estimate for compound 4 lay 1.3-fold (0.10 log units) above the measured number; low and high end bracket the measured number.
By their numbers in this assay, from the lowest: compounds 3 and 4 (each within the scatter of the next); then compound 1. At a limit, above all of these: compound 2.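

In this assay, a 1.3-fold higher number from compound 3 to compound 4 (0.12 log units; within the scatter), so this step gives the first readable measure of an aryl exchange on this chain carbon. Going by these compounds alone, the only earlier exchange at such a carbon could not be sized, because one end of it is a limit and not a number: the limit of > 20000 nM in this assay, at which 1 of the 4 values shown sits. Here the entering 4-hydroxy-3-methoxyphenyl brings 9 heavy atoms, 1 hydrogen-bond donor and 2 hydrogen-bond acceptors where the leaving 3-chlorophenyl has 7 heavy atoms and neither donors nor acceptors, yet the scatter does not separate the two numbers, so at this position, with the rest of the structure held as it is, the assay shows no difference between a chlorine-bearing ring and a ring bearing hydroxy and methoxy groups.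

The compounds shown leave open whether the hydroxy group or the methoxy group of the entering ring contributes anything on its own, since no step here exchanges either one alone. They also leave open whether a ring carrying an amine or a carboxylic acid on this chain carbon would give a number that lies beyond the scatter from those of compound 3 and compound 4.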